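The source may report more compounds than this note shows. Statements on the series, on what has been measured and on what is new or still open speak of the compounds shown alone.

Values in a functional assay on HeLa cells (Homo sapiens) for antiproliferative activity, read by MTT assay, with a stated time of 72 h; on this read-out higher numbers stand for weaker inhibition and lower numbers for stronger inhibition:
- compound 1 `COc1ncc(-c2ccc3c(c2)N(c2ccc(F)cc2)C(=O)CO3)cc1NS(=O)(=O)c1ccc(F)cc1` gives 10500 nM
- compound 2 `COc1ncc(-c2ccc3c(c2)N(C2CCCCC2)C(=O)CO3)cc1NS(=O)(=O)c1ccc(F)cc1` gives 6100 nM
- compound 3 `COc1ncc(-c2ccc3c(c2)N(c2ccccc2)C(=O)CO3)cc1NS(=O)(=O)c1ccc(F)cc1` gives 1530 nM

Compound 3 has the lowest number of the three, and its steps to both others lie beyond the scatter. Compound 4 `COc1ccc(N2C(=O)COc3ccc(-c4cnc(OC)c(NS(=O)(=O)c5ccc(F)cc5)c4)cc32)cc1` is next, with methoxy in place of hydrogen on an aromatic carbon, para to a large group: methoxy in place of hydrogen on an aromatic carbon.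

Within the data shown here, no methoxy compound has been measured. The nearest case is a 6.9-fold lower number from compound 1 to compound 3 (0.84 log units; beyond the scatter), with hydrogen in place of fluoro on an aromatic carbon. Read backward, this single case pairs a group entering on phenyl with a higher number. Two further steps concern the whole group on the ring nitrogen: a 4.0-fold lower number from compound 2 to compound 3 (0.60 log units; beyond the scatter) and a 1.7-fold lower number from compound 1 to compound 2 (0.24 log units; within the scatter), the latter within the scatter. Neither speaks directly to methoxy.

A modest rise in this assay is therefore expected, of similar or smaller size than the fluoro case. The expected change is a 3.3-fold higher number from compound 3 to compound 4 (0.51 log units; beyond the scatter). For compound 4 the estimated value is 5000 nM, with an expected range from 1500 nM to 15000 nM.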

Compound 4, half-maximal inhibitory concentration: 1220 nM
Compound 4: middle estimate off by 4.1-fold (0.61 log units), on the high side, outside the stated range (below it).
By their numbers in this assay, from the lowest: compounds 4 and 3 (each within the scatter of the next); then compounds 2 and 1 (each within the scatter of the next).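

In this assay, methoxy on an aromatic carbon para to a large group leaves the read-out within the scatter of the unsubstituted phenyl (a 1.3-fold lower number from compound 3 to compound 4 (0.10 log units; within the scatter)), so a group entering at this position need not raise the number. Fluoro and methoxy part clearly here (an 8.6-fold lower number from compound 1 to compound 4 (0.93 log units; beyond the scatter)), and the single fluoro case therefore does not extend to methoxy. The 4-methoxyphenyl group also stands clear of cyclohexyl on the ring nitrogen (a 5.0-fold lower number from compound 2 to compound 4 (0.70 log units; beyond the scatter)), while no measurement at hand accounts for the gap between fluoro and methoxy.

Open, on these data alone, is how other groups behave at this position, for example a dimethylamino group or a carboxylic acid. Also open, as far as these compounds go, is whether methoxy is tolerated equally on other carbons of this phenyl ring.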